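The source may hold more compounds than are shown below. What is called first, only, known or untested is meant among the compounds shown, and "the series" means these compounds.

Going by the values given here, compound 2 `O=S(=O)(NCCCNCc1ccc(Cl)cc1)c1cc(C(F)(F)F)cc(C(F)(F)F)c1` gives 3000 nM in a functional assay on ASPC1 cells (Homo sapiens) for inhibition, read by MTT assay, with a stated time of 72 h (on this read-out higher numbers stand for weaker inhibition of growth and lower numbers for stronger inhibition of growth), the lowest of the three numbers known here. Compound 1 `O=S(=O)(NCCCNCc1cccc2ccccc12)c1cc(C(F)(F)F)cc(C(F)(F)F)c1` gives 21000 nM in this assay, and compound 3 `O=S(=O)(NCCCNCc1ccc(Cl)c(C(F)(F)F)c1)c1cc(C(F)(F)F)cc(C(F)(F)F)c1` gives 9600 nM. The known steps all turn on the aromatic group bound to the amine nitrogen: a 7.0-fold lower number from compound 1 to compound 2 (0.85 log units; beyond the scatter), a 2.2-fold lower number from compound 1 to compound 3 (0.34 log units; beyond the scatter), and a 3.2-fold higher number from compound 2 to compound 3 (0.51 log units; beyond the scatter). Compound 4 `COc1ccccc1CNCCCNS(=O)(=O)c1cc(C(F)(F)F)cc(C(F)(F)F)c1` differs from compound 2 in the same region: 2-methoxyphenyl in place of 4-chlorophenyl on a saturated chain carbon bound to an amine nitrogen. Among the compounds with values here, no measured step tells how a methoxy group, or this placement on the ring, behaves in this assay. Within the data shown here, what the three compounds do show is that the one step away from 4-chlorophenyl, a 3.2-fold higher number from compound 2 to compound 3 (0.51 log units; beyond the scatter), raised the number, while compound 2 stands at the bottom of the set. A modest rise is therefore the expected outcome, with the expected step being a 2.3-fold higher number from compound 2 to compound 4 (0.37 log units; beyond the scatter). For compound 4 the estimate in this assay is 7000 nM, expected to lie between 2500 nM and 20000 nM.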

Compound 4, concentration for 50% growth inhibition: 4600 nM
The estimate for compound 4 lay 1.5-fold (0.18 log units) above the measured number; measured number inside the range.
By their numbers in this assay, from the lowest: compounds 2 and 4 (each within the scatter of the next); then compound 3; then compound 1.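

In this assay, 2-methoxyphenyl on a saturated chain carbon bound to an amine nitrogen cannot be told apart from 4-chlorophenyl, with a 1.5-fold higher number from compound 2 to compound 4 (0.19 log units; within the scatter). Going by these compounds alone, this position therefore accepts a methoxy-bearing ring without chlorine and stays at the low end of the set, which the earlier compounds could not show: the steps from the other two groups, a 2.1-fold lower number from compound 3 to compound 4 (0.32 log units; beyond the scatter) and a 4.6-fold lower number from compound 1 to compound 4 (0.66 log units; beyond the scatter), run in the same direction as those to compound 2. No measurement given here accounts for these numbers.

As far as these compounds go, whether the methoxy group or its placement on the ring matters more remains open, and a 4-methoxyphenyl or a 2-chlorophenyl group would help separate the two. From the compounds shown here alone, how a pyridine ring would read at this position, or a longer chain in the shared core, is also open.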